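A few compounds are considered here, and "the series" means these few. Any claim that something is new, unique, unknown or untested is made for them only; others in the source may bear on it.

In a functional assay on MT4 cells (Homo sapiens) for cytotoxicity (a lower number here means a stronger inhibitor, a higher number a weaker inhibitor), compound 1 (`Cc1cc(Cl)cc(Sc2cccc(N)c2C#N)c1`) gives 16000 nM. Compound 2 (`N#Cc1c(N)cccc1S(=O)(=O)c1ccccc1`) reads > 5000 nM, which is a limit and not a number. Compound 3 (`COc1ccc(S(=O)(=O)c2cccc(N)c2C#N)cc1`) reads > 200000 nM, which is likewise only a limit. Compound 4 (`Cc1ccc(S(=O)(=O)c2cccc(N)c2C#N)cc1`) has methyl in place of methoxy on an aromatic carbon, para to a large group: methyl in place of methoxy on an aromatic carbon. Among the compounds with values here, the one measured step involving this methoxy group is a step that the two limits leave unreadable from compound 2 to compound 3, so it gives no size to carry over. Within the data shown here, only a modest move toward a lower number is therefore expected, with compound 1 at 16000 nM as the sole measured number. The expected change is an at least 2.0-fold lower number from compound 3 to compound 4 (0.30 log units; that floor lies within the scatter). For compound 4 the estimate is 100000 nM, with an expected range of 20000 nM to 300000 nM.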

Compound 4, half-maximal inhibitory concentration: > 200000 nM
Compound 4 gave a limit, no number (the forecaster's own chance of this, stated with the estimate: 60%); middle value at least 2.0-fold (0.30 log units) away from the limit.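

In this assay, within the data shown here, compound 2, compound 3 and compound 4 all read as limits, so no step among them can be read. From the compounds shown here alone, how methoxy, methyl and hydrogen on that aromatic carbon compare remains open.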